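This account rests on a few compounds, and the source may have more. Where it says the series, first, only, none or still open, it means among the compounds named here.

The series shares the core seen in compound 1 `O=C(Cn1cc(COc2ccc3c(c2)CCC3)nn1)Nc1cccc(Cl)c1` and compound 3 `COc1cccc(NC(=O)Cn2cc(COc3ccc4c(c3)CCC4)nn2)c1`, for which an ADME assay on HEK293 cells (Homo sapiens) for inhibition, read by MTT assay, with a stated time of 48 h, tested at 25 uM (a lower number here means less inhibition, a higher number more inhibition at the concentration tested (going by the name of the read-out)), records for compound 1 "not determined" (no result reported) and for compound 3 "not determined" (no result reported). Among the measured compounds shown here, compound 2 `Cc1ccc(-n2cc(COc3ccc4c(c3)CCC4)nn2)c(C)c1` is the only member with a number: in this assay compound 2 gives 19.9%, a modest degree of inhibition at the tested concentration. On the numbers shown, compound 2 therefore stands alone, with no other value to set beside it. Compound 4 `Brc1ccccc1-n1cc(COc2ccc3c(c2)CCC3)nn1` has yet to be measured in this assay. For the measured compounds named here, it differs from compound 2 in a single place, namely (2-bromophenyl in place of 2,4-dimethylphenyl on an aromatic nitrogen), and no pair of measured compounds shows what such a change does, so there is no measured step to lean on. Because compound 2 gives 19.9% and nothing in the data points either way, the expected step from compound 2 to compound 4 is a number 0.1 percentage points higher from compound 2 to compound 4 (within the scatter), which is not expected to exceed the usual scatter in either direction. Compound 4 is accordingly estimated at 20%, with a range from 5% to 38%.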

Compound 4, a percentage reported as inhibition, at one concentration (the size of the read-out at that concentration, not a potency): 16.5%
Compound 4: middle estimate off by 3.5 percentage points, on the high side, and the stated range covers the measured number.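

In this assay, among the compounds shown here, the exchange on the aromatic nitrogen gives the first measured step at this position, a number 3.4 percentage points lower from compound 2 to compound 4 (within the scatter), so compound 2 and compound 4 cannot be told apart. At this level of inhibition, 2-bromophenyl and 2,4-dimethylphenyl, each a single six-membered aromatic ring of carbon only with no hydrogen-bond donors or acceptors, read alike in this one comparison. No supporting evidence accompanies the result to account for it.

Steps to compound 1 and compound 3 cannot be read, so the two aryl compounds cannot be set against the amide-bearing members of the series. From the compounds shown here alone, it remains open what an amine or a carboxylic acid on the aromatic nitrogen would give, and whether the bromine or the two methyl groups contribute anything separately.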